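Ring on the amide carbon and half-life in human microsomes

The source may report more compounds than this note shows. Statements on the series, on what has been measured and on what is new or still open speak of the compounds shown alone.

Measured in an in vitro ADME assay on microsomes (Homo sapiens) for metabolic stability (a lower number here means that the compound disappears faster, a higher number that the compound lasts longer), as follows
- compound 1 `Cc1c2c(n3c1CCN(C(=O)CN)C[C@@H](C)[C@H](C)Nc1cc-3ccc1C(N)=O)CC(C)(C)CC2=O` gives > 0.5 h as a limit
- compound 2 `CC[C@H](N)C(=O)N1CCc2c(C)c3c(n2-c2ccc(C(N)=O)c(c2)N[C@@H](C)[C@H](C)C1)CC(C)(C)CC3=O` gives 0.417 h as its value
- compound 3 `Cc1c2c(n3c1CCN(C(=O)C1(N)CC1)C[C@@H](C)[C@H](C)Nc1cc-3ccc1C(N)=O)CC(C)(C)CC2=O` gives 0.0667 h as its value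

Compound 1 stands at a limit and not at a number (the limit of > 0.5 h in this assay, at which 1 of the 3 values shown sits). Compound 4 `Cc1c2c(n3c1CCN(C(=O)C1(N)CCCC1)C[C@@H](C)[C@H](C)Nc1cc-3ccc1C(N)=O)CC(C)(C)CC2=O` is not yet measured. It carries 1-aminocyclopentyl in place of aminomethyl on a carbonyl carbon. The nearest measured change, 1-aminocyclopropyl in place of aminomethyl, gave a modest drop at the least (an at least 7.4-fold lower number from compound 1 to compound 3 (0.87 log units; beyond the scatter)). The open-chain change with ethyl shows only a floor within the scatter (an at least 1.1-fold lower number from compound 1 to compound 2 (0.07 log units; that floor lies within the scatter)). Between these two, the ring gave a modest drop as well (a 6.3-fold lower number from compound 2 to compound 3 (0.80 log units; beyond the scatter)). The expectation therefore leans on compound 3 (0.0667 h), the measured compound with a ring at that place. The step expected in this assay is a lower number of similar size (an at least 5.0-fold lower number from compound 1 to compound 4 (0.69 log units; beyond the scatter)). Compound 4 is estimated at 0.1 h with 0.04 h to 0.35 h as its expected range.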

Compound 4, half-life: 0.0667 h
Compound 4: middle estimate off by 1.5-fold (0.18 log units), on the high side; the measured number falls inside the stated range.
By their numbers in this assay, from the lowest: compounds 3 and 4 (each within the scatter of the next); then compound 2. At a limit, above all of these: compound 1.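

In this assay, widening the ring on the carbonyl carbon from 1-aminocyclopropyl to 1-aminocyclopentyl left the half-life unchanged: no change at the digits printed from compound 3 to compound 4 (within the scatter). The larger ring therefore matches the drop seen with the smaller one, giving a 6.3-fold lower number from compound 2 to compound 4 (0.80 log units; beyond the scatter) and an at least 7.4-fold lower number from compound 1 to compound 4 (0.87 log units; beyond the scatter). The size of the step from compound 1 is only a floor, as compound 1 stands at a limit: the limit of > 0.5 h in this assay, at which 1 of the 4 values shown sits.

Still open, from the compounds shown here alone, is whether 1-aminocyclohexyl, or a ring carrying an oxygen atom, would give the same half-life at this place. Also open, going by these compounds, is how far compound 1 actually lies from the ringed compounds.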